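A few compounds are considered here, and "the series" means these few. Any claim that something is new, unique, unknown or untested is made for them only; others in the source may bear on it.

Three compounds share one core and differ only in the aryl group that sits on a saturated chain carbon bound to an amine nitrogen and a saturated chain carbon. In an ADME assay on Vero cells (Chlorocebus sabaeus) for cytotoxicity, read by MTT assay, with a stated time of 72 h (a lower number here means that less compound is tolerated, a higher number that more compound is tolerated), compound 1 `N/C(=N/NC(CC(=O)c1ccc(-n2ccnc2)cc1)c1ccc(F)cc1)c1ccccn1` gives 78800 nM, compound 2 `N/C(=N/NC(CC(=O)c1ccc(-n2ccnc2)cc1)c1ccccc1Cl)c1ccccn1` gives 53200 nM, and compound 3 `N/C(=N/NC(CC(=O)c1ccc(-n2ccnc2)cc1)c1ccc(Cl)cc1Cl)c1ccccn1` gives 27800 nM. Compound 3 thus gives the lowest of the three numbers in this assay, though the step of a 1.9-fold lower number from compound 2 to compound 3 (0.28 log units; within the scatter) does not reach beyond the scatter, while the step of a 2.8-fold lower number from compound 1 to compound 3 (0.45 log units; beyond the scatter) is the only one here that stands beyond the scatter; the step of a 1.5-fold lower number from compound 1 to compound 2 (0.17 log units; within the scatter) is small.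

Compound 4 `N/C(=N/NC(CC(=O)c1ccc(-n2ccnc2)cc1)c1cccc(Br)c1)c1ccccn1` is the next variation: 3-bromophenyl in place of 2,4-dichlorophenyl on a saturated chain carbon bound to an amine nitrogen and a saturated chain carbon. Within the data shown here, no measured step swaps one halogen pattern for another in this way. The two single-halogen compounds, compound 1 and compound 2, both sit higher than the dichloro compound 3, so returning to a single halogen is expected to bring a step of a 1.8-fold higher number from compound 3 to compound 4 (0.25 log units; within the scatter), upward, of modest size. For compound 4 the estimated value in this assay is 50000 nM, within a range from 25000 nM to 100000 nM.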

Compound 4, half-maximal cytotoxic concentration: 51300 nM
Beside the measured number, compound 4's estimate is 1.0-fold (0.01 log units) below it; the range from low to high includes it.
By their numbers in this assay, from the lowest: compounds 3, 4, 2 and 1 (each within the scatter of the next, the first and the last beyond it).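

In this assay, the 3-bromophenyl group of compound 4 puts the only bromine of the series on this aryl ring, and the result lies within the scatter of the other two single-halogen compounds (a 1.0-fold lower number from compound 2 to compound 4 (0.02 log units; within the scatter); a 1.5-fold lower number from compound 1 to compound 4 (0.19 log units; within the scatter)). The step from the dichloro compound also lies within the scatter (a 1.8-fold higher number from compound 3 to compound 4 (0.27 log units; within the scatter)), so compound 4 cannot be told apart from compound 1, compound 2 or compound 3, even though compound 1 and compound 3 differ beyond the scatter. No measurement is available to explain these numbers.

Compound 4 changes both the halogen and its place on the ring, so the two changes cannot be separated. From the compounds shown here alone, whether a plain phenyl, or a phenyl carrying an amine or a carboxylic acid, would fall in this same range remains open.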